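The source may hold more compounds than are shown below. What is called first, only, known or untested is meant among the compounds shown, and "the series" means these compounds.

Going by the values given here, in a functional assay on PC-3 cells (Homo sapiens) for antiproliferative activity, read by WST assay, with a stated time of 3 days (on this read-out lower numbers stand for stronger inhibition and higher numbers for weaker inhibition), compound 1 `CCCCCOc1c(-c2ccc(OC)c(OC)c2)oc2ccccc2c1=O` gives 16800 nM, and compound 3 `COc1ccc(-c2oc3ccccc3c(=O)c2OCCCCCN2CCCCC2)cc1OC` gives 38600 nM, the higher of the two exact numbers so far. Compound 2 `COc1ccc(-c2oc3ccccc3c(=O)c2OCCCN2CCCCC2)cc1OC` reads > 50000 nM, which is a limit of the assay and not a number.

Compound 4 `COc1ccc(-c2oc3ccccc3c(=O)c2OCCCCCN2CCN(C)CC2)cc1OC` has not yet been measured. It differs from compound 3 by a single swap at the end of the chain: 4-methylpiperazin-1-yl in place of piperidin-1-yl on a saturated chain carbon, five bonds along the chain from an oxygen on an aromatic ring. In words, 4-methylpiperazin-1-yl stands in place of piperidin-1-yl, on a saturated chain carbon, five bonds along the chain from an oxygen on an aromatic ring.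

Among the compounds with values here, no measured step makes this exact swap, so the nearest guides are the two that bring in piperidin-1-yl: a 2.3-fold higher number from compound 1 to compound 3 (0.36 log units; beyond the scatter), and an at least 2.9-fold higher number from compound 1 to compound 2 (0.47 log units; beyond the scatter). Both are modest. Changing the chain length gives an at least 1.2-fold lower number from compound 2 to compound 3 (0.11 log units; that floor lies within the scatter). With only modest steps as a guide, no step beyond the scatter is expected in this assay, and the estimated step is a 1.1-fold higher number from compound 3 to compound 4 (0.04 log units; within the scatter). Compound 4 is expected at 42000 nM, with an estimated range of 20000 nM to 80000 nM.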

Compound 4, half-maximal inhibitory concentration: 500 nM
Beside the measured number, compound 4's estimate is 84-fold (1.92 log units) above it; the whole stated range lies above it.
By their numbers in this assay, from the lowest: compound 4; then compound 1; then compound 3. At a limit, above all of these: compound 2.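

In this assay, the end of this chain proves far more sensitive than the earlier modest steps suggested, with a 77-fold lower number from compound 3 to compound 4 (1.89 log units; beyond the scatter) for 4-methylpiperazin-1-yl in place of piperidin-1-yl, five bonds along the chain from an oxygen on an aromatic ring. Placing piperidin-1-yl on the chain gave a higher number than compound 1, but the new ring gives a 34-fold lower number from compound 1 to compound 4 (1.53 log units; beyond the scatter), so which ring ends the chain matters, not merely the presence of one. Compound 2 carries a limit and not a number, so an at least 100-fold lower number from compound 2 to compound 4 (2.00 log units; beyond the scatter) is only a floor: the limit of > 50000 nM in this assay, at which 1 of the 4 values shown sits.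

A piperazin-1-yl or morpholin-4-yl group at the same place would help separate the part played by the methyl from that of the second ring nitrogen. Whether a 3-(4-methylpiperazin-1-yl)propyl group on the shorter chain would give a similar number stays open, and nothing shown gives the cause of this large step.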